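Removing the trifluoromethyl from compound 3

A few compounds are considered here, and "the series" means these few. Any claim that something is new, unique, unknown or untested is made for them only; others in the source may bear on it.

Measured compounds:
- Compound 1, `O=C(NO)c1ccc(Cn2nnc(-c3cccc(S(F)(F)(F)(F)F)c3)n2)cc1`: 26 nM
- Compound 2, `Nc1ccc(-c2nnn(Cc3ccc(C(=O)NO)cc3)n2)cc1`: 1 nM
- Compound 3, `O=C(NO)c1ccc(Cn2nnc(-c3ccc(C(F)(F)F)cc3)n2)cc1`: 11 nM

In an assay on Sf9 cells for inhibition of protein deacetylase HDAC6 (Homo sapiens), read by fluorescence (on this read-out higher numbers stand for weaker inhibition and lower numbers for stronger inhibition), compound 3 gives 11 nM, the second highest of the three numbers. Its nearest neighbour is compound 1, whose value in this assay is 26 nM, and the furthest is compound 2 at 1 nM.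

Compound 4, `O=C(NO)c1ccc(Cn2nnc(-c3ccccc3)n2)cc1`, is not yet measured. It differs from compound 3 in one place:

hydrogen in place of trifluoromethyl on an aromatic carbon

Within the data shown here, only one measured step touches the same position: an 11-fold higher number from compound 2 to compound 3 (1.04 log units; beyond the scatter). That step swaps one group for another rather than removing one, so it bears on the new step only loosely. It shows that the group on this carbon matters, with amino giving the lowest number of the three. Among the measured compounds shown here, a bare hydrogen lies between the two cases in character, and no measured pair tells where it falls. The expected step from compound 3 to compound 4 is therefore modest and uncertain in direction: a 1.2-fold lower number from compound 3 to compound 4 (0.09 log units; within the scatter).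

Compound 4 is expected to give about 9 nM in this assay, within a range from 3 nM to 30 nM.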

Compound 4, half-maximal inhibitory concentration: 3 nM
Estimate against measurement, compound 4: 3.0-fold (0.48 log units) above; low and high end bracket the measured number.
By their numbers in this assay, from the lowest: compound 2; then compound 4; then compound 3; then compound 1.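

In this assay, among these compounds, the bare hydrogen serves as a reference point that the earlier compounds lacked, and a 3.7-fold lower number from compound 3 to compound 4 (0.56 log units; beyond the scatter) shows that trifluoromethyl on this aromatic carbon goes with weaker inhibition than no group at all. Hydrogen does not match amino, however: a 3.0-fold higher number from compound 2 to compound 4 (0.48 log units; beyond the scatter) places amino on the stronger side of hydrogen, so the single earlier swap from amino to trifluoromethyl now divides into two steps in the same direction, with hydrogen standing in the middle. The sulfur and fluorine group of compound 1 also sits on the weaker side of hydrogen, as an 8.7-fold lower number from compound 1 to compound 4 (0.94 log units; beyond the scatter) shows, so among these compounds a group on the aromatic ring raises the number over hydrogen, and compound 2 goes against that pattern.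

Nothing shown here gives a reason for any of these steps.

Going by these compounds, it remains open whether the lower number belongs to amino alone or would also appear with a hydroxyl group or a dimethylamino group on this carbon. On these data alone, it is also open where a carboxylic acid or a nitrile at the same place would fall relative to hydrogen.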